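This account rests on a few compounds, and the source may have more. Where it says the series, first, only, none or still open, it means among the compounds named here.

Three compounds have already been measured in an assay for displacement of a labelled ligand from DNA repair protein REV1 (Homo sapiens), read by fluorescence polarization, with a stated time of 1 h; a lower number here means a stronger inhibitor, a higher number a weaker inhibitor:

Compound 1, `CC(=O)N1CCC(C(=O)Nc2sc3c(c2C(=O)NC2CC2)CCC(C)C3)CC1`, gives 2500 nM.
Compound 2, `CCc1ccc(NC(=O)CN2CCN(c3ccc(F)cc3)CC2)cc1`, gives 2500 nM.
Compound 3, `COC(=O)c1cc(C)sc1NC(=O)C1CCN(C(C)=O)CC1`, gives 9400 nM.

On these numbers compound 1 and compound 2 stand level at the digits shown, a difference within the usual scatter, and together they are the lowest of the three. Compound 3 sits furthest from compound 1, with a clearly higher number, a gap that lies beyond the scatter.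

The compound to be measured next is compound 4, `CC(=O)N1CCC(C(=O)Nc2sc3c(c2C(N)=O)CCC(C)C3)CC1`. It is compound 1 with hydrogen in place of cyclopropyl on an amide-type nitrogen, so the amide keeps its carbonyl and nitrogen but loses the three-membered ring that was attached there. Among the measured compounds shown here, no two measured compounds differ from each other in a single place, so there is no measured step of this kind to lean on. For the measured compounds named here, since the change removes only that one ring, the number in this assay is expected to stay close to that of compound 1 or move somewhat higher, a step expected to lie near the edge of the scatter. Compound 4 is therefore expected to give 3500 nM, with a range from 1200 nM to 12000 nM. This corresponds to an expected step of a 1.4-fold higher number from compound 1 to compound 4 (0.15 log units; within the scatter) in this assay.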

Compound 4, half-maximal inhibitory concentration: 13200 nM
Compound 4: middle estimate off by 3.8-fold (0.58 log units), on the low side; the whole stated range lies below it.
By their numbers in this assay, from the lowest: compounds 1 and 2 (each within the scatter of the next); then compounds 3 and 4 (each within the scatter of the next).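

Putting hydrogen in place of cyclopropyl on the amide-type nitrogen gives, in this assay, a 5.3-fold higher number from compound 1 to compound 4 (0.72 log units; beyond the scatter). Among the compounds shown here, this is the first comparison here between two compounds that differ in only one place, and it shows that the group on this nitrogen matters: of this pair, compound 1, which carries the cyclopropyl, is the stronger inhibitor. No supporting measurement is available to explain this difference.

The compounds shown leave open whether the three-membered ring itself is needed or whether another carbon group on the same nitrogen, such as methyl, isopropyl or a longer chain, would serve equally well. They also leave open whether a larger group, such as a phenyl ring, would give a lower number than compound 1 in this assay.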